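Ring-opened amine in place of methylpiperazine on the core

A few compounds are considered here, and "the series" means these few. Any claim that something is new, unique, unknown or untested is made for them only; others in the source may bear on it.

The three measured compounds share one core, a thioether-linked acetamide bearing an anilide. In an assay on isolated protein for inhibition of Ectonucleotide pyrophosphatase/phosphodiesterase family member 1 (Homo sapiens), tested at 10 uM (on this read-out higher numbers stand for more inhibition at the one concentration tested (going by the name of the read-out) and lower numbers for less inhibition), compound 1 `O=C(CSc1nc2cccnc2[nH]1)Nc1ccc(Cl)c(Cl)c1` gives 10%. Compound 2 `O=C(CSc1nc2cccnc2[nH]1)Nc1cccc(Br)c1` gives 23% in this assay. Compound 3 `COc1ccc(NC(=O)CSc2nc3ccc(N4CCN(C)CC4)nc3[nH]2)cc1OC`, which carries a 4-methylpiperazin-1-yl group on the fused core, gives 35% in this assay. Compound 3 stands highest of the three numbers: compound 2 is nearest, lower by a gap beyond the usual scatter, and compound 1 is furthest, also beyond the scatter. For the measured compounds named here, no two measured compounds differ in only one place, so no single-point step is available to lean on.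

Compound 4 `COc1ccc(NC(=O)CSc2nc3ccc(N(C)C)nc3[nH]2)cc1OC` is not yet measured. It differs from compound 3 in one place: dimethylamino in place of 4-methylpiperazin-1-yl on an aromatic carbon. Nothing measured here isolates the effect of such a change, so the expectation rests on compound 3 alone. A small step is expected, a number 8 percentage points lower from compound 3 to compound 4 (within the scatter), pointing downward by no more than the usual scatter. Compound 4 is expected to give about 27% in this assay, within a range from 8% to 45%.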

Compound 4, a percentage reported as inhibition, at one concentration (the size of the read-out at that concentration, not a potency): 58%
Estimate against measurement, compound 4: 31 percentage points below, outside the stated range (above it).
By their numbers in this assay, from the lowest: compound 1; then compound 2; then compound 3; then compound 4.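

In this assay, for the compounds shown here, dimethylamino in place of 4-methylpiperazin-1-yl on this aromatic carbon gives a number 23 percentage points higher from compound 3 to compound 4 (beyond the scatter) and supplies the first single-place comparison. The position is therefore not indifferent to the amine it carries, and with this dimethyl-substituted anilide the open-chain group reads higher than the ring at the one concentration tested, something compound 1 and compound 2 could not show, as each differs from compound 3 in more than one place. No measurement at hand accounts for this step.

Still open, as far as these compounds go, is whether the ring or merely its second nitrogen matters: morpholin-4-yl, pyrrolidin-1-yl or a plain amino group on the same carbon would separate these. Also open, from the compounds shown here alone, is whether dimethylamino at this position gives a similar step with the halogenated anilides of compound 1 and compound 2.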